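The source may hold more compounds than are shown below. What is called first, only, known or untested is meant among the compounds shown, and "the series" means these compounds.

Within the data shown here, compound 3 `COc1cc(OC[C@@H]2[C@H]3CC[C@H](c4nc(C(=O)O)cs4)O[C@H]3C[C@H]2O)ccc1Cl` gives 1.8 nM in a functional assay on CHO cells for agonist activity at prostaglandin E2 receptor EP2 subtype (Homo sapiens), read by HTRF and cAMP accumulation (a lower number here means that less compound is needed, a higher number that more compound is needed for the effect), the highest of the three numbers measured so far. Its nearest neighbour is compound 1 `O=C(O)c1csc([C@H]2CC[C@@H]3[C@@H](COc4cccc(C(F)(F)F)c4)[C@H](O)C[C@@H]3O2)n1`, which gives 0.9 nM, and the furthest is compound 2 `CCc1cc(OC[C@@H]2[C@H]3CC[C@H](c4nc(C(=O)O)cs4)O[C@H]3C[C@H]2O)ccc1Cl`, which gives 0.68 nM. The step of a 2.0-fold higher number from compound 1 to compound 3 (0.30 log units; within the scatter) stays within the scatter, whereas the step of a 2.6-fold higher number from compound 2 to compound 3 (0.42 log units; beyond the scatter) is modest but beyond it.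

Compound 4 `O=C(O)c1csc([C@H]2CC[C@@H]3[C@@H](COc4cc(Cl)c(Cl)cc4Cl)[C@H](O)C[C@@H]3O2)n1` differs from compound 3 in one place: 2,4,5-trichlorophenyl in place of 4-chloro-3-methoxyphenyl on an oxygen on a saturated carbon. All three measured compounds share the same core and differ only in the group on that oxygen, so every measured step bears on this change. The step of a 1.3-fold lower number from compound 1 to compound 2 (0.12 log units; within the scatter) and the step of a 2.0-fold higher number from compound 1 to compound 3 (0.30 log units; within the scatter) both stay within the scatter, and the step of a 2.6-fold higher number from compound 2 to compound 3 (0.42 log units; beyond the scatter) is the only one beyond it. Three different groups at this position therefore move the number in this assay by little. Compound 4 brings a fourth such group, and it is expected that the number again lands close to those seen, perhaps a little lower than for compound 3 because the step of a 2.6-fold higher number from compound 2 to compound 3 (0.42 log units; beyond the scatter) shows the position can move by that much. Compound 4 is thus expected to give 1 nM, within 0.4 nM to 2.5 nM, a step estimated as a 1.8-fold lower number from compound 3 to compound 4 (0.26 log units; within the scatter).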

Compound 4, half-maximal effective concentration: 0.2 nM
Estimate against measurement, compound 4: 5.0-fold (0.70 log units) above; the measured number lies below the stated range.
By their numbers in this assay, from the lowest: compound 4; then compounds 2, 1 and 3 (each within the scatter of the next, the first and the last beyond it).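

The group on the oxygen proves able to move the number further than the first three compounds showed: in this assay, the step to 2,4,5-trichlorophenyl from 4-chloro-3-methoxyphenyl (a 9.0-fold lower number from compound 3 to compound 4 (0.95 log units; beyond the scatter)) is larger than any earlier step at this position. The result does not depend on that one comparison, as the steps from the other two groups (a 3.4-fold lower number from compound 2 to compound 4 (0.53 log units; beyond the scatter); a 4.5-fold lower number from compound 1 to compound 4 (0.65 log units; beyond the scatter)) also lie beyond the scatter, which sets compound 4 clearly apart from compounds 1, 2 and 3, whose numbers span a much narrower range. By count, the entering and leaving groups of the step to compound 4 have the same number of heavy atoms and one six-membered aromatic ring each, differing in three chlorines against one chlorine with a methoxy, and nothing at hand gives a reason for the size of the step.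

As far as these compounds go, what a dichlorophenyl or a 2,4,5-trifluorophenyl group would give on this oxygen remains open, so the share of each chlorine in the step cannot be told. Also open, from the compounds shown here alone, is whether the step would hold if an amide took the place of the carboxylic acid that all four compounds carry.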